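This account rests on a few compounds, and the source may have more. Where it says the series, first, only, none or still open, it means among the compounds named here.

Four compounds share a core built from two linked rings and a sulfonyl group, and differ only in the groups at two outer positions. Compound 1 `N#Cc1ccc(S(=O)(=O)N2C/C(=C\c3ccncc3)C(=O)/C(=C/c3ccccc3F)C2)cc1` is the starting point. In an ADME assay on L02 cells (Homo sapiens) for cytotoxicity, read by MTT assay, with a stated time of 24 h (a lower number here means a stronger inhibitor, a higher number a weaker inhibitor), compound 1 gives only a limit, > 20000 nM, which is the limit of the method (the limit of > 20000 nM in this assay, at which 1 of the 3 values shown sits). Compound 2 `CC(=O)Nc1ccc(S(=O)(=O)N2C/C(=C\c3ccncc3)C(=O)/C(=C/c3ccccc3F)C2)cc1` carries the change acetamido in place of cyano on an aromatic carbon and in this assay compound 2 gives 12300 nM, so the step of an at least 1.6-fold lower number from compound 1 to compound 2 (0.21 log units; that floor lies within the scatter) is measured against a limit. Compound 3 `N#Cc1ccc(S(=O)(=O)N2C/C(=C\c3cccnc3)C(=O)/C(=C/c3ccccc3C(F)(F)F)C2)cc1` has a different core; how its core differs from that of compound 1 is not broken down here. In this assay compound 3 gives 13200 nM. Compound 4 `CC(=O)Nc1ccc(S(=O)(=O)N2C/C(=C\c3cccnc3)C(=O)/C(=C/c3ccccc3C(F)(F)F)C2)cc1` carries the same change on the core of compound 3, (acetamido in place of cyano on an aromatic carbon). Because the earlier step of an at least 1.6-fold lower number from compound 1 to compound 2 (0.21 log units; that floor lies within the scatter) rests on a limit, only a small step of a 1.2-fold lower number from compound 3 to compound 4 (0.08 log units; within the scatter) is expected. Compound 4 is estimated at 11000 nM, between 5000 nM and 25000 nM.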

Compound 4, half-maximal inhibitory concentration: 15300 nM
The estimate for compound 4 lay 1.4-fold (0.14 log units) below the measured number, within the range that was stated.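

On the core of compound 3, acetamido in place of cyano gives a 1.2-fold higher number from compound 3 to compound 4 (0.06 log units; within the scatter), so on this core this assay shows no change that stands out from the usual scatter. Set beside the step on the core of compound 1, the comparison stays unsettled: the same change on two cores in this assay, an at least 1.6-fold lower number (0.21 log units; that floor lies within the scatter) from compound 1 to compound 2 and a 1.2-fold higher number (0.06 log units; within the scatter) from compound 3 to compound 4; the limit leaves it open whether they differ

Compound 1 gives > 20000 nM, which is a limit and not a number, and whether the change carries over unchanged from one core to the other is neither shown nor ruled out.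

Only cyano and acetamido appear at this place in the compounds shown. From the compounds shown here alone, what an amine, a carboxylic acid or a longer chain would give there remains open, as does how the change reads on a further core where both partners give numbers.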